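From 3-fluorophenyl to furan-2-yl at the histamine H2 receptor

A few compounds are considered here, and "the series" means these few. Any claim that something is new, unique, unknown or untested is made for them only; others in the source may bear on it.

Of the compounds shown here, three have been measured in an assay on membranes from Sf9 cells for displacement of a labelled ligand from histamine H2 receptor (Homo sapiens), read by scintillation counting, with a stated time of 60 min; a higher number here means a weaker inhibitor, a lower number a stronger inhibitor. Compound 1 `CCCNC(=O)/N=C(\N)Nc1cccc(-c2csc(N)n2)c1` gives 5250 nM, compound 3 `Cc1nc(N)sc1CCCN/C(N)=N/C(=O)NC(c1ccccc1)c1ccccc1` gives 43.7 nM, and compound 2 `Cc1nc(N)sc1CCCN/C(N)=N/C(=O)NC(C)c1cccc(F)c1` gives 2.04 nM, the lowest of the three numbers. Its gaps to compound 3 and to compound 1 both lie beyond the usual scatter, so compound 2 is the strongest inhibitor of the set. Compound 4 `Cc1nc(N)sc1CCCN/C(N)=N/C(=O)NC(C)c1ccco1` differs from compound 2 in a single place: furan-2-yl in place of 3-fluorophenyl on a saturated chain carbon bound to an amide-type nitrogen and a saturated chain carbon. Among the measured compounds shown here, no measured pair shows this exact change, so its effect is unknown from the data. Taking compound 2 as the anchor, the step of a 2.5-fold higher number from compound 2 to compound 4 (0.39 log units; beyond the scatter) is expected to be small, with a slight weakening more likely than a gain. Compound 4 is therefore estimated at 5 nM, within a range from 1.5 nM to 20 nM.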

Compound 4, inhibition constant: 31.6 nM
Compound 4: middle estimate off by 6.3-fold (0.80 log units), on the low side; measured number above the stated range.
By their numbers in this assay, from the lowest: compound 2; then compounds 4 and 3 (each within the scatter of the next); then compound 1.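

Furan-2-yl in place of 3-fluorophenyl gives a 15-fold higher number from compound 2 to compound 4 (1.19 log units; beyond the scatter), a large weakening. This is the first pair among these compounds that differs only at this saturated chain carbon, and it shows that binding here depends strongly on which aromatic ring the carbon carries. No measured evidence accounts for the size of this step. Still open, going by these compounds, is how a plain phenyl, thiophen-2-yl or pyridyl ring would fare at this carbon. Also open, on these data alone, is how much of the stronger binding of compound 2 depends on its fluorine.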